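Bromo for Chloro on the Shared Core

The source may report more compounds than this note shows. Statements on the series, on what has been measured and on what is new or still open speak of the compounds shown alone.

Compound 1: `C=C(C)C(=O)c1ccc(OCc2nc(C)no2)cc1Cl`, 2100 nM
Compound 2: `C=C(C)C(=O)c1ccc(OCc2nc(-c3ccccc3)no2)cc1Cl`, 600 nM
Compound 3: `C=C(C)C(=O)c1ccc(OCc2nc(-c3ccc(C(F)(F)F)cc3)no2)cc1Cl`, 700 nM

In an assay on HL-60 cells for inhibition of glutathione S-transferase P (Homo sapiens) (on this read-out higher numbers stand for weaker inhibition and lower numbers for stronger inhibition), compound 2 and compound 3 lie within the scatter of each other, while compound 1 sits apart: a 3.5-fold lower number from compound 1 to compound 2 (0.54 log units; beyond the scatter). The step from compound 2 to compound 3, a 1.2-fold higher number from compound 2 to compound 3 (0.07 log units; within the scatter), changes nothing that is distinguishable from repeat measurement.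

Compound 4, `C=C(C)C(=O)c1ccc(OCc2nc(-c3ccccc3)no2)cc1Br`, differs from compound 2 in one place: bromo in place of chloro on an aromatic carbon. Neither measured step bears on this change, since both of them alter the group on the five-membered ring rather than the halogen on the shared core; the halogen at this position has not been varied among the measured compounds. Going by the values given here, with no step to lean on, the plain expectation is a number that stays close to compound 2 and within the scatter. The number for compound 4 in this assay is therefore estimated at 600 nM, with a range from 300 nM to 1200 nM. That estimate amounts to no change at the digits printed from compound 2 to compound 4 (within the scatter), a step expected to fall within the scatter.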

Compound 4, half-maximal inhibitory concentration: 2000 nM
Beside the measured number, compound 4's estimate is 3.3-fold (0.52 log units) below it, outside the stated range (above it).
By their numbers in this assay, from the lowest: compounds 2 and 3 (each within the scatter of the next); then compounds 4 and 1 (each within the scatter of the next).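

The halogen on the shared core, ortho to a (1-methylethenyl)carbonyl group, proves not to be a silent place: in this assay, bromo in place of chloro gives a 3.3-fold higher number from compound 2 to compound 4 (0.52 log units; beyond the scatter). This is the only change at this place among the compounds shown, and it lies beyond the scatter, whereas the earlier steps touched only the group on the five-membered ring. No measurement at hand accounts for this step, which stands here as an observation only.

Bromo appears only in compound 4, alongside its phenyl, so it remains open whether the step would hold with the methyl of compound 1 or the trifluoromethyl-bearing phenyl of compound 3. Also open, from the compounds shown here alone, is how fluoro, methyl or a nitrile at this same place would read in this assay.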